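Swapping the Amide Aryl Group on a Weak Cytotoxic Imide

A few compounds are considered here, and "the series" means these few. Any claim that something is new, unique, unknown or untested is made for them only; others in the source may bear on it.

Compound 1, `CCc1cccc(NC(=O)c2cccc(/C=C3\CC(=O)N(Cc4ccccc4)C3=O)c2)c1`: 91500 nM
Compound 2, `O=C(Nc1ccc(OC(F)F)cc1)c1cccc(/C=C2\CC(=O)N(c3ccccc3)C2=O)c1`: > 100000 nM

In an ADME assay on SW480 cells (Homo sapiens) for cytotoxicity, read by MTT assay, with a stated time of 72 h (a lower number here means a stronger inhibitor, a higher number a weaker inhibitor), compound 1 gives 91500 nM. Compound 2 reached only the assay limit, > 100000 nM, so no number is known for it; it stands at the limit of > 100000 nM in this assay, at which 1 of the 2 values shown sits. Compound 3, `CCc1cccc(NC(=O)c2cccc(/C=C3\CC(=O)N(c4ccccc4)C3=O)c2)c1`, is not yet measured and carries 3-ethylphenyl in place of 4-(difluoromethoxy)phenyl on an amide-type nitrogen. Going by the values given here, no measured step exists for this change, and compound 1, which shares the 3-ethylphenyl amide, also shows weak inhibition, so no movement beyond the scatter is expected. Compound 3 is expected at 95000 nM, ranging from 40000 nM to 250000 nM. The expected change is an at least 1.0-fold lower number from compound 2 to compound 3 (0.02 log units; that floor lies within the scatter).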

Compound 3, half-maximal inhibitory concentration: 88600 nM
Compound 3: the middle estimate sits 1.1-fold (0.03 log units) above what was measured, and the stated range covers the measured number.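

With the 3-ethylphenyl amide kept, phenyl in place of benzyl on an amide-type nitrogen in a ring gives a 1.0-fold lower number from compound 1 to compound 3 (0.01 log units; within the scatter), so this change leaves the reading unmoved beyond the scatter. With 3-ethylphenyl in place of 4-(difluoromethoxy)phenyl on the amide-type nitrogen, the result is an at least 1.1-fold lower number from compound 2 to compound 3 (0.05 log units; that floor lies within the scatter), which guarantees only a small change. Compound 2 has a limit rather than a number: the limit of > 100000 nM in this assay, at which 1 of the 3 values shown sits.

On these data alone, the true distance between compound 2 and compound 3 therefore stays open. So does whether an amine or a carboxylic acid on the amide's phenyl ring would shift the number beyond the scatter.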